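The source may hold more compounds than are shown below. What is called first, only, known or untested is meant among the compounds shown, and "the series" means these compounds.

Measured in a functional assay on UO-31 cells (Homo sapiens) for antiproliferative activity, read by sulforhodamine B assay, with a stated time of 72 h; on this read-out lower numbers stand for stronger inhibition and higher numbers for weaker inhibition:
compound 1 `Cc1cc(C)nc(NS(=O)(=O)c2ccc(Nc3nncc4ccccc34)cc2)n1`: 3.4 nM
compound 2 `O=S(=O)(Nc1ncccn1)c1ccc(Nc2nncc3ccccc23)cc1`: 23 nM
compound 3 `O=S(=O)(Nc1ccccn1)c1ccc(Nc2nncc3ccccc23)cc1`: 44 nM

In this assay, the gap to compound 2 lies within the scatter, at a 1.9-fold higher number from compound 2 to compound 3 (0.28 log units; within the scatter), while the gap to compound 1 is large, at a 13-fold higher number from compound 1 to compound 3 (1.11 log units; beyond the scatter). Compound 4 `Cc1cc(NS(=O)(=O)c2ccc(Nc3nncc4ccccc34)cc2)no1` has 5-methyl-1,2-oxazol-3-yl in place of pyridin-2-yl on a sulfonamide nitrogen. The three measured steps all fall at this nitrogen, but none covers the entering ring. Within the data shown here, the only clear separation involves compound 1, seen also in a 6.8-fold higher number from compound 1 to compound 2 (0.83 log units; beyond the scatter), so this one case supports only a slight lean towards a lower number. The expected step is a 1.8-fold lower number from compound 3 to compound 4 (0.25 log units; within the scatter), which stays within the scatter. For compound 4 the estimate is 25 nM, with an expected range of 6 nM to 100 nM.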

Compound 4, half-maximal inhibitory concentration: 33 nM
Beside the measured number, compound 4's estimate is 1.3-fold (0.12 log units) below it; measured number inside the range.
By their numbers in this assay, from the lowest: compound 1; then compounds 2, 4 and 3 (each within the scatter of the next).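

In this assay the five-membered 5-methyl-1,2-oxazol-3-yl ring on the sulfonamide nitrogen stays within the scatter of both the pyridin-2-yl (a 1.3-fold lower number from compound 3 to compound 4 (0.12 log units; within the scatter)) and the pyrimidin-2-yl (a 1.4-fold higher number from compound 2 to compound 4 (0.16 log units; within the scatter)) groups. Among these compounds, the 4,6-dimethylpyrimidin-2-yl group stands apart from this ring as well (a 9.7-fold higher number from compound 1 to compound 4 (0.99 log units; beyond the scatter)), so it remains the only group here that separates from the others. No measurement at hand explains this.

Open, going by these compounds, is whether a single methyl on the pyrimidin-2-yl ring would be enough to give that separation. Also open, on these data alone, is how a phenyl ring or a carboxylic acid-bearing group on this nitrogen would compare.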